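The compounds below may be only part of what the source reports. "The series", "measured", "known", "first", "only" and "open" are said of these compounds alone.

Measured compounds:
- compound 1, `Cc1cccc(C(=O)n2c(-c3cn(-c4ccccc4)nc3-c3ccc(C(F)(F)F)cc3)nc3ccccc32)c1`: 154000 nM
- compound 2, `Cc1ccc(C(=O)n2c(-c3cn(-c4ccccc4)nc3-c3ccc(F)cc3)nc3ccccc32)cc1`: 178000 nM
- compound 3, `Cc1ccc(-c2nn(-c3ccccc3)cc2-c2nc3ccccc3n2C(=O)c2cccc(C)c2)cc1`: 195000 nM

In an ADME assay on HEK-293T cells (Homo sapiens) for cytotoxicity, read by MTT assay, with a stated time of 24 h (on this read-out lower numbers stand for higher toxicity in this test and higher numbers for lower toxicity in this test), compound 3 gives the highest of the three numbers, though all three lie within the scatter of one another. Compound 4, `Cc1cccc(C(=O)n2c(-c3cn(-c4ccccc4)nc3-c3ccc(F)cc3)nc3ccccc32)c1`, differs from compound 3 by one change: fluoro in place of methyl on an aromatic carbon. The only step of this kind in the set is a 1.3-fold higher number from compound 1 to compound 3 (0.10 log units; within the scatter), which stayed within the scatter. Compound 2, which carries the same fluoro group on a differently placed methyl, gives a number close to that of compound 3. For compound 4 in this assay no movement beyond the scatter is therefore expected, and the estimated step is a 1.1-fold lower number from compound 3 to compound 4 (0.05 log units; within the scatter). Compound 4 is expected to give about 175000 nM, between 100000 nM and 300000 nM.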

Compound 4, half-maximal cytotoxic concentration: 148000 nM
Compound 4: the middle estimate sits 1.2-fold (0.07 log units) above what was measured; measured number inside the range.
By their numbers in this assay, from the lowest: compounds 4, 1, 2 and 3 (each within the scatter of the next).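

In this assay the position para to a large group now holds three different groups with no movement beyond the scatter: fluoro in place of methyl gives a 1.3-fold lower number from compound 3 to compound 4 (0.12 log units; within the scatter) and fluoro in place of trifluoromethyl gives a 1.0-fold lower number from compound 1 to compound 4 (0.02 log units; within the scatter). With fluoro held fixed, 3-methylphenyl in place of 4-methylphenyl on the carbonyl carbon also stays within the scatter, at a 1.2-fold lower number from compound 2 to compound 4 (0.08 log units; within the scatter). Nothing available explains these results. On these data alone, whether an amine or a carboxylic acid at this position would move the number beyond the scatter remains open.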